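The source may hold more compounds than are shown below. What is called first, only, known or untested is meant among the compounds shown, and "the series" means these compounds.

Measured so far:
- compound 1 `O=C(NO)c1ccc(/C=C/c2ccnc(-c3cc(F)ccc3O)c2)cc1`: 130 nM
- compound 2 `O=C(NO)c1ccc(/C=C/c2ccnc(-c3cccnc3)c2)cc1`: 14 nM

Both compounds were tested in an assay on isolated protein for inhibition of protein deacetylase HDAC6 (Homo sapiens), read by fluorescence, with a stated time of 15 min; on this read-out higher numbers stand for weaker inhibition and lower numbers for stronger inhibition. Compound 1 gives 130 nM, while compound 2 gives 14 nM, so compound 1 shows the higher of the two numbers, and the gap between them, a 9.3-fold lower number from compound 1 to compound 2 (0.97 log units; beyond the scatter), lies beyond the usual scatter. Compound 3 `O=C(NO)c1ccc(/C=C/c2ccnc(Br)c2)cc1` has not yet been measured. It differs from compound 1 in one place: bromo in place of 5-fluoro-2-hydroxyphenyl on an aromatic carbon. Among the measured compounds shown here, only one measured step bears on this change, a 9.3-fold lower number from compound 1 to compound 2 (0.97 log units; beyond the scatter), and it removed the same 5-fluoro-2-hydroxyphenyl group from the same aromatic carbon, though pyridin-3-yl entered there rather than bromo. That single comparison shows a modest drop in number when the 5-fluoro-2-hydroxyphenyl group leaves, and bromo is a far smaller replacement than pyridin-3-yl, so the outcome is uncertain. The number for compound 3 is nevertheless expected to fall below that of compound 1, by roughly a 3.3-fold lower number from compound 1 to compound 3 (0.51 log units; beyond the scatter). Compound 3 is estimated at 40 nM, with a likely range from 10 nM to 160 nM.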

Compound 3, half-maximal inhibitory concentration: 320 nM
The estimate for compound 3 lay 8.0-fold (0.90 log units) below the measured number, outside the stated range (above it).
By their numbers in this assay, from the lowest: compound 2; then compound 1; then compound 3.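

In this assay, losing the 5-fluoro-2-hydroxyphenyl group from this aromatic carbon next to the ring nitrogen does not in itself lower the number: bromo in its place gives a 2.5-fold higher number from compound 1 to compound 3 (0.39 log units; beyond the scatter), the opposite direction to the change seen with pyridin-3-yl. The lower number of compound 2 therefore cannot be read simply as the result of the 5-fluoro-2-hydroxyphenyl group leaving, and what enters at this position matters, as a 23-fold higher number from compound 2 to compound 3 (1.36 log units; beyond the scatter) shows. Among these three compounds, the two groups carrying a ring both give lower numbers than the single bromine atom, although those two ring groups also differ clearly from each other.

No measurement is available that explains why these groups rank as they do. A plain phenyl group at this carbon would help to show whether the ring alone or the ring nitrogen of pyridin-3-yl goes with the lowest number, while an amine or a morpholine ring would show how far this position tolerates groups of other kinds.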